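Aryl variation on the shared thiourea core, toward compound 3

The source may report more compounds than this note shows. Statements on the series, on what has been measured and on what is new or still open speak of the compounds shown alone.

Compound 1 `NS(=O)(=O)c1ccc(NC(=S)Nc2ccc3ncnc(Nc4ccc(Cl)c(C(F)(F)F)c4)c3c2)cc1`: in a functional assay on A549 cells (Homo sapiens) for antiproliferative activity, read by MTT assay, with a stated time of 72 h (a higher number here means a weaker inhibitor, a lower number a stronger inhibitor), compound 1 gives 4500 nM.
Compound 2 `NS(=O)(=O)c1ccc(NC(=S)Nc2ccc3ncnc(Nc4cccc(Cl)c4F)c3c2)cc1`: in this assay compound 2 reaches only the limit of > 40000 nM.

Compound 2 stands at the limit, with no number of its own, as noted in the limit of > 40000 nM in this assay, at which 1 of the 2 values shown sits. Going by the values given here, the single measured step, an at least 8.8-fold higher number from compound 1 to compound 2 (0.94 log units; beyond the scatter), shows that the aryl on the nitrogen sets the number, as far as two compounds can show. Compound 3 `NS(=O)(=O)c1ccc(NC(=S)Nc2ccc3ncnc(Nc4cccc(F)c4)c3c2)cc1` carries 3-fluorophenyl in place of 3-chloro-2-fluorophenyl on a nitrogen on an aromatic ring. Among the compounds with values here, no measured step covers this exact change, so the bearing of an at least 8.8-fold higher number from compound 1 to compound 2 (0.94 log units; beyond the scatter) is only that such aryl changes move the number widely. A change an at least 1.3-fold lower number from compound 2 to compound 3 (0.12 log units; that floor lies within the scatter) is expected, its direction uncertain. Compound 3 is estimated at 30000 nM, within 6000 nM to 80000 nM.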

Compound 3, half-maximal inhibitory concentration: 25900 nM
Compound 3: the middle estimate sits 1.2-fold (0.06 log units) above what was measured; measured number inside the range.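

Against the 4-chloro-3-(trifluoromethyl)phenyl group, the 3-fluorophenyl group also gives a weaker result in this assay: a 5.8-fold higher number from compound 1 to compound 3 (0.76 log units; beyond the scatter), so compound 1 remains the strongest of the three. The other step reads an at least 1.5-fold lower number from compound 2 to compound 3 (0.18 log units; that floor lies within the scatter), which does not separate the 3-fluorophenyl and 3-chloro-2-fluorophenyl groups. That step stays a floor because compound 2 has only a limit, not a number: the limit of > 40000 nM in this assay, at which 1 of the 3 values shown sits.

Whether the chlorine or the trifluoromethyl of the 4-chloro-3-(trifluoromethyl)phenyl group accounts for the lower number of compound 1 stays open. So does the outcome with a methoxy group or an amine on this aryl ring.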